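This account rests on a few compounds, and the source may have more. Where it says the series, first, only, none or still open, it means among the compounds named here.

Compound 3 `O=C(/C=C\c1ccc(F)cc1)N1N=C(c2ccncc2)OC1c1c[nH]c2ccccc12` carries a 4-fluorophenyl on a double-bonded chain carbon bound to a double-bonded chain carbon. In an ADME assay on PANC-1 cells (Homo sapiens) for cytotoxicity, read by MTT assay, with a stated time of 48 h (on this read-out lower numbers stand for stronger inhibition of growth and higher numbers for weaker inhibition of growth), compound 3 gives only a limit of the assay, > 30 ug/mL. Compound 1 `O=C(/C=C\c1ccccc1)N1N=C(c2ccncc2)OC1c1c[nH]c2ccccc12` also gives a limit in this assay, > 30 ug/mL. Compound 2 `O=C(/C=C\c1cccc(O)c1)N1N=C(c2ccncc2)OC1c1c[nH]c2ccccc12` gives a limit as well, > 30 ug/mL. The steps a step that the two limits leave unreadable from compound 1 to compound 3 and a step that the two limits leave unreadable from compound 2 to compound 3 therefore cannot be sized, because of the limit of > 30 ug/mL in this assay, at which 3 of the 3 values shown sit. Compound 4 `O=C(/C=C\c1ccccc1Cl)N1N=C(c2ccncc2)OC1c1c[nH]c2ccccc12` differs from compound 3 by 2-chlorophenyl in place of 4-fluorophenyl on a double-bonded chain carbon bound to a double-bonded chain carbon. Among the measured compounds shown here, no measured step resolves a change of this kind, so nothing beyond the scatter is expected for a step that the limit leaves unreadable from compound 3 to compound 4. Compound 4 is thus expected to give about 40 ug/mL, within 15 ug/mL to 120 ug/mL, most likely again reported as a limit.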

Compound 4, concentration for 50% growth inhibition: > 30 ug/mL
Compound 4: no number, only a limit; the forecaster's own chance of this, stated with the estimate: 80%; the middle value does not contradict the limit.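

No step can be read from compound 4 to compound 1, compound 2 or compound 3 in this assay, because all four give only a limit: the limit of > 30 ug/mL in this assay, at which 4 of the 4 values shown sit.

Still open, going by these compounds, is how these compounds truly rank in growth inhibition, and whether any of these aromatic changes alters it.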